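Swapping the Chain-End Amine on a Weaker Triazole Amide

The compounds below may be only part of what the source reports. "The series", "measured", "known", "first", "only" and "open" are said of these compounds alone.

The measured compounds:
compound 1, `COc1cc2c(Oc3ccc(NC(=O)c4cn(-c5ccccc5F)nn4)cc3F)ccnc2cc1OCCCN1CCC(C)CC1`, which in a functional assay on NCI-H460 cells (Homo sapiens) for cytotoxicity, read by MTT assay, with a stated time of 72 h (a higher number here means a weaker inhibitor, a lower number a stronger inhibitor), gives 190 nM;
compound 2, `COc1cc2c(Oc3ccc(NC(=O)c4cn(-c5ccccc5C)nn4)cc3F)ccnc2cc1OCCCN1CCC(C)CC1`, which in this assay gives 2730 nM;
compound 3, `COc1cc2c(Oc3ccc(NC(=O)c4cn(-c5c(C)cccc5C)nn4)cc3F)ccnc2cc1OCCCN1CCC(C)CC1`, which in this assay gives 2360 nM.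

Compound 3 stands second highest of the three numbers. Compared with compound 2 the difference is small: a 1.2-fold lower number from compound 2 to compound 3 (0.06 log units; within the scatter). Compared with compound 1 it is large: a 12-fold higher number from compound 1 to compound 3 (1.09 log units; beyond the scatter), and the change from compound 1 to compound 2 was of the same kind: a 14-fold higher number from compound 1 to compound 2 (1.16 log units; beyond the scatter).

Compound 4, `COc1cc2c(Oc3ccc(NC(=O)c4cn(-c5c(C)cccc5C)nn4)cc3F)ccnc2cc1OCCCN1CCN(C)CC1`, keeps everything of compound 3 except the amine at the end of the chain: 4-methylpiperazin-1-yl in place of 4-methylpiperidin-1-yl on a saturated chain carbon, three bonds along the chain from an oxygen on an aromatic ring. None of the three measured steps bears on this change. Going by the values given here, each of them altered only the ring on the triazole nitrogen and left the chain-end amine untouched, so the data give no measured step from which to read the effect of this swap.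

With nothing to point in either direction, the expectation for compound 4 in this assay is a step no larger than the scatter: a 1.0-fold higher number from compound 3 to compound 4 (0.01 log units; within the scatter). As far as these compounds go, the estimate for compound 4 is therefore 2400 nM, with a range from 700 nM to 8000 nM, kept wide to reflect that this kind of change is untested here.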

Compound 4, half-maximal inhibitory concentration: 4540 nM
Compound 4: the middle estimate sits 1.9-fold (0.28 log units) below what was measured; measured number inside the range.
By their numbers in this assay, from the lowest: compound 1; then compounds 3, 2 and 4 (each within the scatter of the next).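

Going by these compounds alone, compound 4 gives the first measured look at the chain end, where the earlier compounds changed only the ring on the aromatic nitrogen. In this assay, the swap of the amine at the end of the chain gives a 1.9-fold higher number from compound 3 to compound 4 (0.28 log units; within the scatter). With the 2,6-dimethylphenyl group held in place, then, exchanging one ring carbon of the chain-end amine for a nitrogen produces no step that can be told apart from the scatter, and no measurement shown here offers an explanation for this result.

As far as these compounds go, it remains open whether the same amine swap would also give a step this small on compound 1, which carries 2-fluorophenyl and gives 190 nM in this assay. The compounds shown also leave open how a different chain end, such as morpholine or dimethylamine, or a butyl chain in place of the propyl chain, would read in this assay.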